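The source may hold more compounds than are shown below. What is called first, only, known or untested is meant among the compounds shown, and "the series" means these compounds.

Working notes on the series in a functional assay on MDA-MB-231 cells (Homo sapiens) for cytotoxicity, read by MTT assay; on this read-out higher numbers stand for weaker inhibition and lower numbers for stronger inhibition. Compound 1 `c1ccc(Cc2nnc(-c3c[nH]c4ccccc34)o2)cc1` gives in this assay only a limit, > 1000000 nM. Compound 2 `COc1ccc(-c2nnc(-c3c[nH]c4ccccc34)o2)cc1` likewise returns a limit in this assay, > 1000000 nM. Compound 3 `COc1ccc(-c2nnc(-c3c[nH]c4ccccc34)o2)c(OC)c1OC` also sits at a limit in this assay, > 1000000 nM. For the measured compounds named here, no numbers are available; all three values sit at the limit of > 1000000 nM in this assay, at which 3 of the 3 values shown sit, so nothing separates the three compounds and no step between them can be sized. Compound 4 `Cc1nnc(-c2c[nH]c3ccccc23)o1` is the unmeasured member; it differs from compound 1 by hydrogen in place of phenyl on a saturated chain carbon bound to an aromatic carbon, in words: hydrogen in place of phenyl on a saturated chain carbon bound to an aromatic carbon. Going by the values given here, with compound 1 at a limit > 1000000 nM and no measured step anywhere in the set, the change is expected to produce no movement beyond the scatter, and compound 4 is expected to remain at the limit as well. The expected step of a number no higher from compound 1 to compound 4 (the limit leaves the size open) is therefore essentially none. Compound 4 is estimated at 1000000 nM, with a range from 300000 nM to 3000000 nM, and most likely reported again only as a limit.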

Compound 4, half-maximal inhibitory concentration: > 1000000 nM
Compound 4: no number, only a limit; the forecaster's own chance of this, stated with the estimate: 90%; the middle value sits exactly at the limit.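

The step from benzyl to methyl between compound 1 and compound 4 cannot be read, because both values are limits: the limit of > 1000000 nM in this assay, at which 4 of the 4 values shown sit. The compounds shown leave open how the four compare with one another and whether any change to the shared core yields a measurable value.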